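The source may report more compounds than this note shows. Statements on the series, on what has been measured and on what is new or still open speak of the compounds shown alone.

Compound 2 `CC(C)(C)OC(=O)N1CCN(C(=O)CCN2C(=O)CSc3ccccc32)CC1` gives 51500 nM in a functional assay (MiaPaCa cells, Homo sapiens) for inhibition, read by sulforhodamine B assay, with a stated time of 48 h (a higher number here means a weaker inhibitor of growth, a lower number a stronger inhibitor of growth), the lowest of the two numbers shown; compound 3 `O=C(CCN1C(=O)CSc2ccccc21)N1CCC(Cc2ccccc2)CC1` gives 56800 nM, which lies within the scatter of that figure. Compound 1 `O=C(CCN1C(=O)CSc2ccccc21)N1CCN(c2ccc(C(F)(F)F)cc2)CC1` gives only a limit of the assay, > 100000 nM. Compound 4 `COc1ccccc1N1CCN(C(=O)CCN2C(=O)CSc3ccccc32)CC1` differs from compound 2 by 2-methoxyphenyl in place of tert-butoxycarbonyl on an amine nitrogen in a ring. Among the measured compounds shown here, the only measured step that bears on this change runs the other way, swapping an aromatic ring for tert-butoxycarbonyl: an at least 1.9-fold lower number from compound 1 to compound 2 (0.28 log units; that floor lies within the scatter), where the floor comes from the limit of > 100000 nM in this assay, at which 1 of the 3 values shown sits. Placing 2-methoxyphenyl on the ring nitrogen is thus expected to move the number upward, if at all, by about a 1.9-fold higher number from compound 2 to compound 4 (0.29 log units; within the scatter). Compound 4 is estimated at 100000 nM, within a range from 40000 nM to 250000 nM.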

Compound 4, concentration for 50% growth inhibition: 34900 nM
Beside the measured number, compound 4's estimate is 2.9-fold (0.46 log units) above it, outside the stated range (below it).
By their numbers in this assay, from the lowest: compounds 4, 2 and 3 (each within the scatter of the next). At a limit, above all of these: compound 1.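

In this assay, an aromatic ring on this ring nitrogen can stand level with tert-butoxycarbonyl, as a 1.5-fold lower number from compound 2 to compound 4 (0.17 log units; within the scatter) shows. The choice of aromatic group counts, since 2-methoxyphenyl in place of 4-(trifluoromethyl)phenyl gives an at least 2.8-fold lower number from compound 1 to compound 4 (0.45 log units; beyond the scatter). Compound 1 stands at a limit of the assay, so that step is only a floor: the limit of > 100000 nM in this assay, at which 1 of the 4 values shown sits.

The two aromatic groups differ in both their substituent and its place on the ring, and the compounds shown do not separate these two changes. On these data alone, how a plain phenyl or a 4-methoxyphenyl group would read on this nitrogen stays open.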